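Chloro to methoxy on the ether-linked aryl ring

The source may report more compounds than this note shows. Statements on the series, on what has been measured and on what is new or still open speak of the compounds shown alone.

Compound 2 `O=C(O)C[C@@H]1CCCN1c1ccc(Oc2ccc(Cl)cc2)cc1` gives in a functional assay on cells for agonist activity at Free fatty acid receptor 1 (Mus musculus), read by FLIPR and calcium flux, with a stated time of 100 s (a higher number here means that more compound is needed for the effect, a lower number that less compound is needed), only a limit, > 33000 nM. Compound 1 `Cc1cccc(Oc2ccc(N3CCC[C@H]3CC(=O)O)cc2)c1` carries a 3-methylphenyl where compound 2 carries a 4-chlorophenyl. In this assay compound 1 gives 2400 nM; the step of an at least 13-fold higher number from compound 1 to compound 2 (1.13 log units; beyond the scatter) is large, and compound 2 sits at the limit of > 33000 nM in this assay, at which 1 of the 2 values shown sits. Compound 3 `COc1ccc(Oc2ccc(N3CCC[C@H]3CC(=O)O)cc2)cc1` differs from compound 2 by methoxy in place of chloro on an aromatic carbon. Among the measured compounds shown here, only the step from compound 1 to compound 2 bears on this change, and it concerns a different pair of groups at a different place on the ring, so it sets no direct expectation for methoxy against chloro; it does show that the substituent on the ether-linked ring moves the number in this assay strongly. The half-maximal effective concentration of compound 3 is therefore expected anywhere from a return toward the number of compound 1 to another limit, and a moderate drop, an at least 2.7-fold lower number from compound 2 to compound 3 (0.43 log units; beyond the scatter), is taken as the middle expectation. Compound 3 is estimated at 12000 nM in this assay, with a range from 2500 nM to 50000 nM.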

Compound 3, half-maximal effective concentration: > 33000 nM
Compound 3: no number, only a limit (the forecaster's own chance of this, stated with the estimate: 35%); middle value at least 2.7-fold (0.43 log units) away from the limit.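

In this assay compound 3 also gives only a limit, so the step between chloro and methoxy cannot be read and neither group can be placed ahead of the other: the limit of > 33000 nM in this assay, at which 2 of the 3 values shown sit. The change from 3-methylphenyl to 4-methoxyphenyl on the oxygen gives an at least 13-fold higher number from compound 1 to compound 3 (1.13 log units; beyond the scatter), a second large step of this kind alongside an at least 13-fold higher number from compound 1 to compound 2 (1.13 log units; beyond the scatter). Chloro and methoxy, each para to a large group, therefore both leave the series without a readable number, and compound 1, with its 3-methylphenyl, is the only one of the three to give a number, 2400 nM.

Both steps from compound 1 change the group and its place on the ring together, so the compounds shown do not say whether the place or the group itself accounts for the loss. A 4-methylphenyl would hold the group of compound 1 at the new place, and a 3-chlorophenyl or 3-methoxyphenyl would hold the groups of compound 2 and compound 3 at the old one, which would separate the two.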